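2,3-Dihydro-1,4-benzodioxin-6-yl in Place of 3,4-Dimethoxyphenyl

The source may report more compounds than this note shows. Statements on the series, on what has been measured and on what is new or still open speak of the compounds shown alone.

Measured compounds:
compound 1 `COc1ccc(C(=O)NC(=S)Nc2cccc(-c3nc4ccccc4[nH]3)c2)cc1OC`: 5000 nM
compound 2 `COc1ccc(C(=O)NC(=O)Nc2cccc(-c3nc4ccccc4[nH]3)c2)cc1OC`: 8000 nM

In a functional assay on HUVEC cells (Homo sapiens) for inhibition, read by colorimetric assay and crystal violet staining, with a stated time of 72 h (on this read-out higher numbers stand for weaker inhibition and lower numbers for stronger inhibition), compound 1 gives 5000 nM, the lower of the two numbers shown. Where compound 1 carries a thiocarbonyl, a carbonyl stands in compound 2, and compound 2 gives 8000 nM; the gap between the two lies within the scatter, so the pair shows no order.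

Compound 3 `O=C(NC(=S)Nc1cccc(-c2nc3ccccc3[nH]2)c1)c1ccc2c(c1)OCCO2` has not yet been measured in this assay. It differs from compound 1 in one place: 2,3-dihydro-1,4-benzodioxin-6-yl in place of 3,4-dimethoxyphenyl on a carbonyl carbon. Both groups carry the same count of heavy atoms and acceptors, and the ring joining the two oxygens is the only thing that is new.

For the measured compounds named here, no step between measured compounds exists to guide this change. The expectation for compound 3 is a small step, from compound 1 to compound 3 of no change at the digits printed from compound 1 to compound 3 (within the scatter), none beyond the scatter. Compound 3 is therefore estimated at 5000 nM, within a range of 2000 nM to 12000 nM.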

Compound 3, half-maximal inhibitory concentration: < 100 nM
Compound 3 was reported as a limit; the forecaster's own chance of this, stated with the estimate: 10%; middle value at least 50-fold (1.69 log units) away from the limit.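

In this assay, 2,3-dihydro-1,4-benzodioxin-6-yl in place of 3,4-dimethoxyphenyl on a carbonyl carbon brings an at least 50-fold lower number from compound 1 to compound 3 (1.69 log units; beyond the scatter). The position therefore responds strongly to this change, even though the counts of heavy atoms, donors and acceptors are the same on both sides and the ring joining the two oxygens is the one new feature, whereas the thiocarbonyl and carbonyl of the earlier pair showed no order. The reading for compound 3 is a limit of the assay, not a number: the limit of < 100 nM in this assay, at which 1 of the 3 values shown sits.

The compounds shown do not tell why the ring has this effect, or whether a carbonyl in place of the thiocarbonyl of compound 3 would keep it. They also leave open whether 1,3-benzodioxol-5-yl, with its five-membered ring, on the same carbonyl carbon would behave like compound 3 or like compound 1.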